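The source may report more compounds than this note shows. Statements on the series, on what has been measured and on what is new or still open speak of the compounds shown alone.

Measured compounds: compound 1 `COc1cc2c(Nc3cc(C(F)(F)F)ccc3F)ncnc2c(OC)c1OC`, with 10300 nM in a functional assay on SGC-7901 cells (Homo sapiens) for antiproliferative activity, read by MTT assay, with a stated time of 72 h; a lower number here means a stronger inhibitor, a higher number a weaker inhibitor; compound 3 `COc1cc2c(Nc3ccc(Br)c(Cl)c3F)ncnc2c(OC)c1OC`, with 15000 nM in this assay. For compound 2 `COc1cc2c(Nc3ccc(F)c(Cl)c3F)ncnc2c(OC)c1OC`, this assay reports only a limit, > 30000 nM.

Compound 2 therefore stands at the edge of what this assay can report, (the limit of > 30000 nM in this assay, at which 1 of the 3 values shown sits), and its true number is not known. Compound 4 `COc1cc2c(Nc3ccc(F)c(Cl)c3)ncnc2c(OC)c1OC` differs from compound 2 by hydrogen in place of fluoro on an aromatic carbon. Among the compounds with values here, the only measured step on this ring, an at least 2.0-fold lower number from compound 2 to compound 3 (0.30 log units; that floor lies within the scatter), concerns a different replacement and offers no direct guide to removing a fluoro. Compound 1 gives 10300 nM in this assay, so all three measured values are weak. The step expected in this assay is an at least 1.5-fold lower number from compound 2 to compound 4 (0.17 log units; that floor lies within the scatter), likely not beyond the scatter. Compound 4 is estimated at 20000 nM, within 7000 nM to 60000 nM.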

Compound 4, half-maximal inhibitory concentration: 5420 nM
Estimate against measurement, compound 4: 3.7-fold (0.57 log units) above; measured number outside the range, below it.
By their numbers in this assay, from the lowest: compounds 4, 1 and 3 (each within the scatter of the next, the first and the last beyond it). At a limit, above all of these: compound 2.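

Hydrogen in place of the fluoro ortho to a chloro group gives an at least 5.5-fold lower number from compound 2 to compound 4 (0.74 log units; beyond the scatter) in this assay, so a change at this position moves the number beyond the scatter. Within the data shown here, the one earlier step, an at least 2.0-fold lower number from compound 2 to compound 3 (0.30 log units; that floor lies within the scatter), replaced the other fluoro, and its floor stayed within the scatter. The new size is only a floor, since compound 2 is reported as a limit: the limit of > 30000 nM in this assay, at which 1 of the 4 values shown sits.

As far as these compounds go, what a methyl group, an amine or a hydroxyl group would do at this position stays open. So does whether removing this fluoro has a similar effect without the neighbouring chloro group.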